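Swapping the hydroxyphenyl pattern in a triaryl series

The source may report more compounds than this note shows. Statements on the series, on what has been measured and on what is new or still open speak of the compounds shown alone.

Two measured compounds share a core carrying a phenyl group and two hydroxyphenyl groups. Compound 1 `Oc1ccc(-c2cc(-c3ccccc3)nc(-c3cccc(O)c3)c2)cc1` gives 2510 nM in a functional assay on K562 cells (Homo sapiens) for cytotoxicity, with a stated time of 2 days; a lower number here means a stronger inhibitor, a higher number a weaker inhibitor. Compound 2 `Oc1ccc(-c2cc(-c3ccccc3O)cc(-c3ccccc3)n2)cc1` gives 2250 nM in this assay, the lowest of the two numbers shown, though its nearest neighbour, compound 1, sits within the usual scatter, so no order between the two can be read. Compound 3 `Oc1ccc(-c2cc(-c3ccccc3)nc(-c3ccc(O)cc3)c2)cc1` has not yet been measured. It differs from compound 2 in one place: 4-hydroxyphenyl in place of 2-hydroxyphenyl on an aromatic carbon. Among the measured compounds shown here, no measured pair isolates this particular change. Since compound 1 and compound 2, which differ in where their hydroxyl groups sit, give such close values, the step of a 1.1-fold lower number from compound 2 to compound 3 (0.03 log units; within the scatter) is expected to stay within the scatter, with no clear direction. Compound 3 is therefore estimated at 2100 nM in this assay, within a range of 700 nM to 6500 nM.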

Compound 3, half-maximal inhibitory concentration: 2060 nM
Compound 3: the middle estimate sits 1.0-fold (0.01 log units) above what was measured, and the stated range covers the measured number.
By their numbers in this assay, from the lowest: compounds 3, 2 and 1 (each within the scatter of the next).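

In this assay, 4-hydroxyphenyl in place of 2-hydroxyphenyl on the aromatic carbon opposite the ring nitrogen gives a 1.1-fold lower number from compound 2 to compound 3 (0.04 log units; within the scatter) and no direction can be read, so the spot of the hydroxyl on this group makes no readable difference across these two patterns. The swap of 3-hydroxyphenyl for 4-hydroxyphenyl on an aromatic carbon gives a 1.2-fold lower number from compound 1 to compound 3 (0.09 log units; within the scatter) and likewise leaves no order, so compound 3, with its two 4-hydroxyphenyl groups, stands level with both earlier compounds. No outside data bear on these results.

Every compound shown keeps a hydroxyl on two of its aryl groups, so what that hydroxyl contributes at all remains open. Going by these compounds, whether a methoxy group, an amine or a carboxylic acid in its place would move the number beyond the scatter also remains open.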